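A few compounds are considered here, and "the series" means these few. Any claim that something is new, unique, unknown or untested is made for them only; others in the source may bear on it.

Working notes on the quinazoline-anilide series, nitroimidazole tail.

Three compounds carry a number in a functional assay on HT-29 cells (Homo sapiens) for cytotoxicity, read by sulforhodamine B assay, with a stated time of 72 h; on this read-out lower numbers stand for stronger inhibition and higher numbers for weaker inhibition. Compound 1 `COc1cc2ncnc(Nc3ccc(F)c(Cl)c3)c2cc1OCCn1ccnc1[N+](=O)[O-]` gives 10000 nM in this assay. Compound 3 `COc1cc2ncnc(Nc3ccc(OCc4cccc(F)c4)c(Cl)c3)c2cc1OCCCn1ccnc1[N+](=O)[O-]` gives 20000 nM in this assay, a number that lies within the scatter of compound 1. Compound 2 `COc1cc2ncnc(Nc3cccc(Br)c3)c2cc1OCCCn1ccnc1[N+](=O)[O-]` gives 4010 nM in this assay, which is lower than compound 1 by more than the scatter. Compound 1 thus stands second highest of the three numbers: within the scatter of compound 3 and beyond it from compound 2.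

Compound 4 `COc1cc2ncnc(Nc3ccc(F)c(Cl)c3)c2cc1OCCn1c([N+](=O)[O-])cnc1C` has not yet been measured. It differs from compound 1 in one place: 2-methyl-5-nitro-1H-imidazol-1-yl in place of 2-nitro-1H-imidazol-1-yl on a saturated chain carbon, two bonds along the chain from an oxygen on an aromatic ring. Going by the values given here, no measured pair shows this change, so nothing in the set tells its direction. Because compound 1 gives 10000 nM and compound 3 gives 20000 nM across a larger change, the step from compound 1 to compound 4 is expected to be small, no change at the digits printed from compound 1 to compound 4 (within the scatter), with no direction beyond the scatter. Compound 4 is estimated at 10000 nM in this assay, within a range of 4000 nM to 25000 nM.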

Compound 4, half-maximal inhibitory concentration: > 50000 nM
Compound 4 was reported as a limit; the forecaster's own chance of this, stated with the estimate: 25%; middle value at least 5.0-fold (0.69 log units) from the limit.
By their numbers in this assay, from the lowest: compound 2; then compounds 1 and 3 (each within the scatter of the next). At a limit, above all of these: compound 4.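

The tail of compound 1 is not a neutral place in this series: with the rest of the molecule held fixed, 2-methyl-5-nitro-1H-imidazol-1-yl in place of 2-nitro-1H-imidazol-1-yl gives an at least 5.0-fold higher number from compound 1 to compound 4 (0.69 log units; beyond the scatter) in this assay. Going by these compounds alone, this is the only single-place change in the set, and it shows that the form of the nitroimidazole on this saturated chain carbon can move the number beyond the scatter. The size of the step stays unread, since the value of compound 4 is a limit: the limit of > 50000 nM in this assay, at which 1 of the 4 values shown sits.

This change joins an added methyl group to a different nitro placement, and the compounds shown do not separate the two. Also open, on these data alone, is how a 5-nitro-1H-imidazol-1-yl without the methyl, a plain 1H-imidazol-1-yl or an amine would read on the same chain.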